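Replacing Isopropyl with Hydrogen on the Chain of Compound 3

The compounds below may be only part of what the source reports. "The series", "measured", "known", "first", "only" and "open" are said of these compounds alone.

In a functional assay on MDA-MB-453 cells (Homo sapiens) for cytotoxicity, read by MTT assay, with a stated time of 72 h (a higher number here means a weaker inhibitor, a lower number a stronger inhibitor), compound 3 (`CC(C)C[C@H](NC1=CC(=O)C=C(C(C)(C)C)C1=O)C(=O)O`) gives 84900 nM, which lies within the scatter of the other two measured compounds: compound 1 (`CC(C)(C)C1=CC(=O)C=C(NCCC(=O)O)C1=O`) gives 94100 nM and compound 2 (`CC(C)(C)C1=CC(=O)C=CC1=O`) gives 56800 nM. Compound 4 (`C[C@H](NC1=CC(=O)C=C(C(C)(C)C)C1=O)C(=O)O`) differs from compound 3 by hydrogen in place of isopropyl on a saturated chain carbon, two bonds along the chain from an amine nitrogen and a carbonyl carbon, with hydrogen in place of isopropyl on a saturated chain carbon, two bonds along the chain from an amine nitrogen and a carbonyl carbon. Going by the values given here, the only measured step, a 1.7-fold lower number from compound 1 to compound 2 (0.22 log units; within the scatter), puts hydrogen in place of (2-carboxyethyl)amino and stays within the scatter. No change beyond the scatter is therefore expected in this assay. The estimated step is a 1.0-fold higher number from compound 3 to compound 4 (0.00 log units; within the scatter). The expected value for compound 4 is 85000 nM, with an estimated range of 48000 nM to 150000 nM.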

Compound 4, half-maximal inhibitory concentration: 112000 nM
Compound 4: middle estimate off by 1.3-fold (0.12 log units), on the low side, and the stated range covers the measured number.
By their numbers in this assay, from the lowest: compounds 2, 3, 1 and 4 (each within the scatter of the next).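

In this assay, going by these compounds alone, hydrogen in place of isopropyl on this saturated chain carbon gives a 1.3-fold higher number from compound 3 to compound 4 (0.12 log units; within the scatter) and so no change beyond the scatter, at a position the earlier compounds did not vary. Likewise, 1-carboxyethyl in place of 2-carboxyethyl on the amine nitrogen gives a 1.2-fold higher number from compound 1 to compound 4 (0.08 log units; within the scatter) and (1-carboxyethyl)amino in place of hydrogen on the double-bonded ring carbon gives a 2.0-fold higher number from compound 2 to compound 4 (0.29 log units; within the scatter) and neither step leaves the scatter. No available evidence bears on these results. As far as these compounds go, whether a longer chain or a phenyl ring on this carbon, or an amine in place of the carboxylic acid, would move the number beyond the scatter remains open.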